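Compound 3 to compound 4: one ring for another

This account rests on a few compounds, and the source may have more. Where it says the series, first, only, none or still open, it means among the compounds named here.

compound 1 `C[Si](C)(C)CCOCn1nnc2c(C(N)=O)ncn2c1=O`: 29900 nM
compound 2 `NC(=O)c1ncn2c(=O)n(Cc3ccco3)nnc12`: > 50000 nM
compound 3 `Cc1cc(Cn2nnc3c(C(N)=O)ncn3c2=O)on1`: > 50000 nM

In a functional assay on SNB-19 cells (Homo sapiens) for inhibition, read by MTT assay, with a stated time of 7 days (a higher number here means a weaker inhibitor of growth, a lower number a stronger inhibitor of growth), compound 1 gives 29900 nM. Compound 2 reads > 50000 nM, which is a limit and not a number. Compound 3 reads > 50000 nM, again only a limit, and so stands at the limit of > 50000 nM in this assay, at which 2 of the 3 values shown sit.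

Compound 4 `NC(=O)c1ncn2c(=O)n(Cc3c[nH]nn3)nnc12` differs from compound 3 in one place: 1H-1,2,3-triazol-4-yl in place of 3-methyl-1,2-oxazol-5-yl on a saturated chain carbon bound to an aromatic nitrogen. For the measured compounds named here, the steps that bear on this are an at least 1.6-fold higher number from compound 1 to compound 2 (0.22 log units; that floor lies within the scatter) and an at least 1.6-fold higher number from compound 1 to compound 3 (0.22 log units; that floor lies within the scatter), each only a floor. The closest one, a step that the two limits leave unreadable from compound 2 to compound 3, gives no size. Both ring-bearing compounds, compound 2 and compound 3, rest at the limit, so no step beyond the scatter is expected. The expected change is a step that the limit leaves unreadable from compound 3 to compound 4. For compound 4 the estimated value is 60000 nM, with an expected range from 30000 nM to 120000 nM.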

Compound 4, concentration for 50% growth inhibition: > 50000 nM
Compound 4 gave a limit, no number (the forecaster's own chance of this, stated with the estimate: 80%); the middle value does not contradict the limit.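

In this assay compound 4 also gives only a limit, not a number, so the steps that join it to compound 2 and to compound 3 cannot be read. For the compounds shown here, the 1H-1,2,3-triazol-4-yl ring, which brings a hydrogen-bond donor, thus joins furan-2-yl and 3-methyl-1,2-oxazol-5-yl on the saturated chain carbon bound to an aromatic nitrogen, and none of the three gives a number: the limit of > 50000 nM in this assay, at which 3 of the 4 values shown sit. The one readable step is only a floor, an at least 1.6-fold higher number from compound 1 to compound 4 (0.22 log units; that floor lies within the scatter).

On these data alone, how far these three compounds lie past the limit stays open. So does what a phenyl ring, an amine or a longer chain would read at this place.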